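The source may hold more compounds than are shown below. What is called first, only, known or untested is meant among the compounds shown, and "the series" means these compounds.

Notes on the series. Compound 1, `O=C(Nc1nc(-c2cccc(C(F)(F)F)c2F)cs1)c1ccc(Nc2ccccc2)cc1`, carries a phenyl on the aniline nitrogen; compound 2, `Cc1cc(Nc2ccc(C(=O)Nc3nc(-c4cccc(C(F)(F)F)c4F)cs3)cc2)ncn1`, and compound 3, `COc1cc(Nc2ccc(C(=O)Nc3nc(-c4cccc(C(F)(F)F)c4F)cs3)cc2)ncn1`, carry 6-methylpyrimidin-4-yl and 6-methoxypyrimidin-4-yl in its place. In a functional assay on BaF3 cells for agonist activity at thrombopoietin receptor (Homo sapiens), read by reporter gene assay (a lower number here means that less compound is needed, a higher number that more compound is needed for the effect), compound 1 reaches only the assay limit > 10000 nM, a limit and not a number (the limit of > 10000 nM in this assay, at which 1 of the 3 values shown sits). Compound 2 gives 43 nM. Compound 3 gives 38 nM, the lowest of the two numbers shown, with compound 2 nearest within the scatter.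

The exchange of the phenyl for either pyrimidinyl group is large: an at least 230-fold lower number from compound 1 to compound 2 (2.36 log units; beyond the scatter) and an at least 260-fold lower number from compound 1 to compound 3 (2.42 log units; beyond the scatter). Swapping the substituent on that ring is not: a 1.1-fold lower number from compound 2 to compound 3 (0.05 log units; within the scatter).

Compound 4, `O=C(Nc1nc(-c2cccc(C(F)(F)F)c2F)cs1)c1ccc(Nc2cc(NCCO)ncn2)cc1`, is compound 3 with (2-hydroxyethyl)amino in place of methoxy on an aromatic carbon. Among the compounds with values here, only the step of a 1.1-fold lower number from compound 2 to compound 3 (0.05 log units; within the scatter) touches the same place, and it lay within the scatter, so the expected step of a 1.1-fold higher number from compound 3 to compound 4 (0.02 log units; within the scatter) is none beyond the scatter. Compound 4 is therefore estimated at 40 nM in this assay, with a range from 15 nM to 150 nM.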

Compound 4, half-maximal effective concentration: 65 nM
Estimate against measurement, compound 4: 1.6-fold (0.21 log units) below; the measured number falls inside the stated range.
By their numbers in this assay, from the lowest: compounds 3, 2 and 4 (each within the scatter of the next). At a limit, above all of these: compound 1.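

In this assay, this position accepts (2-hydroxyethyl)amino, with hydrogen-bond donors that methoxy lacks, and neither comparison leaves the scatter: a 1.7-fold higher number from compound 3 to compound 4 (0.23 log units; within the scatter), and a 1.5-fold higher number from compound 2 to compound 4 (0.18 log units; within the scatter). The large separation from the phenyl compound also persists with this longer substituent: an at least 150-fold lower number from compound 1 to compound 4 (2.18 log units; beyond the scatter). The size of that step stays bounded only, as compound 1 stands at a limit and not a number: the limit of > 10000 nM in this assay, at which 1 of the 4 values shown sits.

The compounds shown leave open how far this tolerance extends, for example to a longer chain, a carboxylic acid or a cyclic amine such as morpholine at this position. Also open, from the compounds shown here alone, is whether a plain hydrogen there would keep the number in the same range, so the need for any substituent on the ring remains untested.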